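The source may hold more compounds than are shown below. What is called first, only, known or untested is meant among the compounds shown, and "the series" means these compounds.

Of the compounds shown here, three sharing one core have been measured in a physicochemical assay for solubility, read by HPLC; on this read-out lower numbers stand for lower solubility and higher numbers for higher solubility. Compound 1 `O=C(c1ccc(Cl)cc1)N1CCN(c2nc(=O)c3cc(C(F)(F)F)cc([N+](=O)[O-])c3s2)CC1` gives 5.19 ug/mL, compound 2 `O=C(C1CC1)N1CCN(c2nc(=O)c3cc(C(F)(F)F)cc([N+](=O)[O-])c3s2)CC1` gives 52.9 ug/mL, and compound 3 `O=C(c1ccc(F)cc1)N1CCN(c2nc(=O)c3cc(C(F)(F)F)cc([N+](=O)[O-])c3s2)CC1` gives 1.69 ug/mL, the lowest of the three numbers. The steps of a 10-fold higher number from compound 1 to compound 2 (1.01 log units; beyond the scatter) and a 31-fold lower number from compound 2 to compound 3 (1.50 log units; beyond the scatter) both set compound 2, whose group on the carbonyl carbon carries no ring, apart from the two compounds bearing a six-membered aromatic ring there. Compound 4 `CC(C)CC(=O)N1CCN(c2nc(=O)c3cc(C(F)(F)F)cc([N+](=O)[O-])c3s2)CC1` differs from compound 3 in one place: isobutyl in place of 4-fluorophenyl on a carbonyl carbon. Isobutyl, like cyclopropyl, brings no ring, so the step of a 31-fold lower number from compound 2 to compound 3 (1.50 log units; beyond the scatter) taken in reverse is the nearest guide, and a large rise in this assay is expected. Compound 4 is therefore estimated at 25 ug/mL, within 8 ug/mL to 70 ug/mL, an expected step of a 15-fold higher number from compound 3 to compound 4 (1.17 log units; beyond the scatter).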

Compound 4, solubility: 66.3 ug/mL
For compound 4 the middle estimate is 2.7-fold (0.42 log units) below the measured one; the range from low to high includes it.
By their numbers in this assay, from the lowest: compound 3; then compound 1; then compounds 2 and 4 (each within the scatter of the next).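

In this assay, isobutyl now joins cyclopropyl as a second group without a ring on the carbonyl carbon, and a 1.3-fold higher number from compound 2 to compound 4 (0.10 log units; within the scatter). Against the two compounds bearing a six-membered aromatic ring there, a 39-fold higher number from compound 3 to compound 4 (1.59 log units; beyond the scatter) and a 13-fold higher number from compound 1 to compound 4 (1.11 log units; beyond the scatter), so the separation at this position no longer rests on cyclopropyl alone. No measurement given here bears on the reason for this separation. Open, on these data alone, is whether cyclohexyl, with its ring of carbon that is not aromatic, would stand with the aromatic groups or with isobutyl. Also open, as far as these compounds go, is how an amine or a carboxylic acid on the chain would compare with isobutyl.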